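Hydroxy in Place of Methyl on the Chain

The source may report more compounds than this note shows. Statements on the series, on what has been measured and on what is new or still open speak of the compounds shown alone.

In an ADME assay on BSC-1 cells (Chlorocebus aethiops) for cytotoxicity, read by WST assay, with a stated time of 20 h (on this read-out lower numbers stand for higher toxicity in this test and higher numbers for lower toxicity in this test), compound 1 `COc1ccc2c(C)nc(N/C(N)=N/C(C)=O)nc2c1` gives 90 uM. Compound 2 `CCC/N=c1\cc(-c2ccccc2)oc2ccc(C)cc12` gives > 200 uM, which is a limit of the test and not a number. Compound 2 therefore sits at the limit of > 200 uM in this assay, at which 1 of the 2 values shown sits. Compound 3 `Cc1ccc2oc(-c3ccccc3)c/c(=N\CCO)c2c1` differs from compound 2 in one place: hydroxy in place of methyl on a saturated chain carbon, two bonds along the chain from a double-bonded nitrogen. In this assay, the estimated step that the limit leaves unreadable from compound 2 to compound 3 is expected to stay within the usual scatter, with no direction favoured. For compound 3, the expected value is 220 uM, with an estimated range of 100 uM to 450 uM.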

Compound 3, half-maximal toxic concentration: > 200 uM
Compound 3: only a limit was reported; the forecaster's own chance of this, stated with the estimate: 60%; the middle value lies beyond the limit too.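

Going by these compounds alone, compound 2 and compound 3 both give only a limit of the test, so no step between them can be read: the limit of > 200 uM in this assay, at which 2 of the 3 values shown sit.

As far as these compounds go, whether hydroxy in place of methyl on the chain changes the half-maximal toxic concentration at all stays open.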